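The source may report more compounds than this note shows. Statements on the series, on what has been measured and on what is new or still open speak of the compounds shown alone.

Measured so far in an ADME assay on blood (Homo sapiens) for pharmacokinetics; on this read-out lower numbers stand for a shorter-lived compound and higher numbers for a longer-lived compound:
- compound 1 `CCc1cc(C(=O)OCO[P@@]2(=O)OCC(C)(C)[C@H](C(=O)NCCC(=O)OC)O2)n(C)n1`: >= 0.97 h, a limit of the assay rather than a number
- compound 2 `COC(=O)CCNC(=O)[C@@H]1O[P@](=O)(OCOC(=O)c2scnc2C(C)(C)C)OCC1(C)C`: 0.44 h
- compound 3 `COC(=O)CCNC(=O)[C@@H]1O[P@@](=O)(OCOC(=O)c2cc(C(C)(C)C)n[nH]2)OCC1(C)C`: > 1 h, also a limit of the assay

Compound 3 thus stands only at a limit in this assay, and so does compound 1, so no ordering between those two can be read. Going by the values given here, the single measured step, a step that the two limits leave unreadable from compound 1 to compound 3, is therefore unreadable in size; it sits at the limit of > 1 h in this assay, at which 1 of the 3 values shown sits, and at the limit of >= 0.97 h in this assay, at which 1 of the 3 values shown sits. Compound 4 `COC(=O)CCNC(=O)[C@@H]1O[P@@](=O)(OCOC(=O)c2scnc2C(C)(C)C)OCC1(C)C` differs from compound 3 by 4-(tert-butyl)-1,3-thiazol-5-yl in place of 3-(tert-butyl)-1H-pyrazol-5-yl on a carbonyl carbon. Among the compounds with values here, no measured step exchanges these two groups, so the step from compound 3 to compound 4 in this assay cannot be predicted from a precedent. One clue is that compound 2 carries the same 4-(tert-butyl)-1,3-thiazol-5-yl group and in this assay compound 2 gives 0.44 h. Compound 4 is therefore expected near 0.6 h, with a range from 0.3 h to 1.2 h. The expected step is an at least 1.6-fold lower number from compound 3 to compound 4 (0.22 log units; that floor lies within the scatter), a shortening, though its size is uncertain.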

Compound 4, half-life: > 1 h
Compound 4: only a limit was reported; the forecaster's own chance of this, stated with the estimate: 25%; middle value at least 1.6-fold (0.22 log units) away from the limit.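

In this assay, the 4-(tert-butyl)-1,3-thiazol-5-yl group does not settle the read-out on its own: there is an at least 2.2-fold higher number from compound 2 to compound 4 (0.35 log units; beyond the scatter), with the group on the carbonyl carbon unchanged. The configuration drawn at the phosphorus stereocentre, R in compound 2 and S in compound 4, is the only thing that can account for this step, because of the following: the fact that compounds 2 and 4 differ only in the configuration as drawn. Compound 1, compound 3 and compound 4 all stand at limits of the assay, so the steps among them cannot be read.

Going by these compounds, it remains open whether the opposite phosphorus configuration would also shorten the half-life with the 3-(tert-butyl)-1H-pyrazol-5-yl group. On these data alone, it is equally open how a phenyl group on the same carbonyl carbon would behave with either configuration at phosphorus.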